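Urea variations on a shared core in adenosine binding

This account rests on a few compounds, and the source may have more. Where it says the series, first, only, none or still open, it means among the compounds named here.

The measured compounds are:
compound 1, `O=C(Nc1ccccc1)Nc1nn(-c2ccccc2)c(=O)c2ccccc12`, giving 44%;
compound 2, `COc1ccccc1CNC(=O)Nc1nn(-c2ccccc2)c(=O)c2ccccc12`, giving 28%;
compound 3, `CC(=O)N(C(C)=O)c1nn(-c2ccccc2)c(=O)c2ccccc12`, giving 47%.

These three share one core and differ only in the substituent on its nitrogen. In an assay on CHO cells for displacement of a labelled ligand from adenosine receptor A1 (Homo sapiens), tested at 10 uM (on this read-out lower numbers stand for less inhibition and higher numbers for more inhibition at the one concentration tested (going by the name of the read-out)), compound 2 stands lowest of the three, with compound 1 nearest and compound 3 furthest, both beyond the scatter above it. Compound 4, `Cc1ccccc1NC(=O)Nc1nn(-c2ccccc2)c(=O)c2ccccc12`, has not yet been measured. The change from compound 2 to compound 4 is 2-methylphenyl in place of 2-methoxybenzyl on an amide-type nitrogen.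

For the measured compounds named here, one measured step bears on this: a number 16 percentage points lower from compound 1 to compound 2 (beyond the scatter). That step exchanged phenyl for 2-methoxybenzyl; the step now considered exchanges 2-methoxybenzyl for 2-methylphenyl, which largely retraces it, ending at a compound closer in build to compound 1 than to compound 2. The account therefore expects a rise of about the size of the measured step, estimated as a number 13 percentage points higher from compound 2 to compound 4 (beyond the scatter). Compound 4 is thus expected to give about 41%, within a range from 26% to 56%.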

Compound 4, a percentage reported as inhibition, at one concentration (the size of the read-out at that concentration, not a potency): 20%
Compound 4: the middle estimate sits 21 percentage points above what was measured; measured number below the stated range.
By their numbers in this assay, from the lowest: compounds 4 and 2 (each within the scatter of the next); then compounds 1 and 3 (each within the scatter of the next).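

In this assay, methyl in place of hydrogen on an aromatic carbon gives a number 24 percentage points lower from compound 1 to compound 4 (beyond the scatter), so at this position a change as small as one methyl is enough to move the number beyond the scatter. The other step, a number 8 percentage points lower from compound 2 to compound 4 (within the scatter), means that 2-methylphenyl and 2-methoxybenzyl on the amide-type nitrogen cannot be told apart here, and that replacing the 2-methoxybenzyl with an aromatic ring bearing a methyl does not restore the number of the unsubstituted phenyl. Nothing shown explains why either step has the size it has.

The compounds shown leave open whether this drop is particular to methyl or would also follow from chlorine, fluorine or a methoxy group on the phenyl. They also leave open how a plain alkyl chain such as butyl would read on the same nitrogen.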